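Dropping the N-methyl: a small step from compound 1

The source may hold more compounds than are shown below. What is called first, only, known or untested is meant among the compounds shown, and "the series" means these compounds.

Measured so far:
- compound 1, `CC(C)c1csc(-c2cccc(CN(C)c3ccc4[nH]nc(C(=O)O)c4c3)c2O)n1`: 35 nM
- compound 2, `Cc1csc(-c2cccc(CN(C)c3ccc4[nH]nc(C(=O)O)c4c3)c2)n1`: 650 nM

In an assay on isolated protein for inhibition of 2-Hydroxyacid oxidase 1 (Homo sapiens), with stated times of 30 min and 15 min (a higher number here means a weaker inhibitor, a lower number a stronger inhibitor), compound 1 gives the lowest of the two numbers, 35 nM, while compound 2 gives 650 nM, a gap that lies beyond the usual scatter. Compound 3, `CC(C)c1csc(-c2cccc(CNc3ccc4[nH]nc(C(=O)O)c4c3)c2O)n1`, has not yet been measured. It differs from compound 1 in one place: hydrogen in place of methyl on a nitrogen on an aromatic ring. Among the compounds with values here, no measured pair shows this change, so its effect is unknown here. A small weakening, or none beyond the scatter, is expected, giving a step of a 1.7-fold higher number from compound 1 to compound 3 (0.23 log units; within the scatter) for compound 3. Compound 3 is estimated at 60 nM, in a range of 15 nM to 250 nM.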

Compound 3, half-maximal inhibitory concentration in the 2-Hydroxyacid oxidase 1 assay: 65 nM
Beside the measured number, compound 3's estimate is 1.1-fold (0.03 log units) below it; low and high end bracket the measured number.
By their numbers in the 2-Hydroxyacid oxidase 1 assay, from the lowest: compounds 1 and 3 (each within the scatter of the next); then compound 2.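

In the 2-Hydroxyacid oxidase 1 assay, replacing the methyl on this nitrogen with hydrogen gives a 1.9-fold higher number from compound 1 to compound 3 (0.27 log units; within the scatter) in this pair, so this methyl is not required for inhibition in the low nanomolar range. In a physicochemical assay for solubility, measured as kinetic solubility, at pH 2 (a lower number here means a less soluble compound, a higher number a more soluble compound), compound 1 gives 175000 nM and compound 3 gives 97000 nM, which is a 1.8-fold lower number from compound 1 to compound 3 (0.26 log units; within the scatter) and shows no real difference in solubility either. Nothing available here explains this result. As far as these compounds go, whether a longer chain such as ethyl, or an acetyl group, on this nitrogen would leave both numbers unchanged remains open.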